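Chain length at the amino hydroxyalkyl end of compound 1

A few compounds are considered here, and "the series" means these few. Any claim that something is new, unique, unknown or untested is made for them only; others in the source may bear on it.

Measured so far:
compound 1 `COc1cc(/C=C/C(=O)/C=C(/C=C/c2ccc(O)c(OC)c2)NCCO)ccc1O` — in a functional assay on Caco-2 cells (Homo sapiens) for activation, read by fluorescence, tested at 1 uM (a lower number here means a stronger effect, a higher number a weaker effect of the compound at the concentration tested), compound 1 gives 103%
compound 2 `COCCCN1C(/C=C/c2ccc(O)cc2)=CC(=O)CC1c1ccc(O)cc1` — in this assay compound 2 gives 99%

The two numbers lie within the scatter of each other; compound 1 does not stand apart from compound 2, and neither shows a marked effect.

Compound 3 `COc1cc(/C=C/C(=O)/C=C(/C=C/c2ccc(O)c(OC)c2)NCCCO)ccc1O` differs from compound 1 by one change: hydroxymethyl in place of hydroxy on a saturated chain carbon, two bonds along the chain from an amine nitrogen. Going by the values given here, no step between measured compounds covers this change. Given that compound 1 gives 103%, no step beyond the scatter is expected from the one added chain carbon. Compound 3 is estimated at 101% (range 90% to 112%), an expected step of a number 2 percentage points lower from compound 1 to compound 3 (within the scatter).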

Compound 3, a percentage reported as activity, at one concentration (the size of the read-out at that concentration, not a potency): 93.4%
Compound 3: the middle estimate sits 7.6 percentage points above what was measured; the measured number falls inside the stated range.
By their numbers in this assay, from the lowest: compounds 3, 2 and 1 (each within the scatter of the next).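

Going from (2-hydroxyethyl)amino to (3-hydroxypropyl)amino at this position gives, in this assay, a number 9.6 percentage points lower from compound 1 to compound 3 (within the scatter), so the one added chain carbon does not set the two compounds apart. Going by these compounds alone, this is the only reading of this change so far, and neither compound shows a marked effect at the concentration tested. No measured evidence bears on this result.

From the compounds shown here alone, whether a longer hydroxyalkyl chain, or a carboxylic acid or an amine in place of the hydroxy, would move the read-out beyond the scatter stays open.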